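Aryl Swap at the Ring Nitrogen: Estimating Compound 4

The compounds below may be only part of what the source reports. "The series", "measured", "known", "first", "only" and "open" are said of these compounds alone.

Compound 1 `CNC(=O)c1cc(Oc2ccc(NC(=O)c3nn(-c4ccccc4C(F)(F)F)c(=O)cc3C)cc2F)ccn1`: in a functional assay on HepG2 cells (Homo sapiens) for cytotoxicity, read by MTT assay, with a stated time of 72 h (a lower number here means a stronger inhibitor, a higher number a weaker inhibitor), compound 1 gives > 40000 nM, a limit of the assay.
Compound 2 `CNC(=O)c1cc(Oc2ccc(NC(=O)c3nn(-c4ccc(Br)cc4F)c(=O)cc3C)cc2F)ccn1`: in this assay compound 2 gives 2830 nM.
Compound 3 `CNC(=O)c1cc(Oc2ccc(NC(=O)c3nn(-c4ccccc4OC(F)(F)F)c(=O)cc3C)cc2F)ccn1`: in this assay compound 3 gives > 40000 nM, a limit of the assay.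

Compound 3 therefore stands at the edge of what this assay reports, with no number of its own; it shares this position with compound 1, since (the limit of > 40000 nM in this assay, at which 2 of the 3 values shown sit). Compound 4 `CNC(=O)c1cc(Oc2ccc(NC(=O)c3nn(-c4cccc(F)c4)c(=O)cc3C)cc2F)ccn1` has not yet been measured. It differs from compound 3 in one place: 3-fluorophenyl in place of 2-(trifluoromethoxy)phenyl on an aromatic nitrogen.

Among the compounds with values here, two measured steps bear on this change. The step of an at least 14-fold higher number from compound 2 to compound 3 (1.15 log units; beyond the scatter) shows that replacing a halogen-bearing phenyl with the 2-(trifluoromethoxy)phenyl pushed the number to the limit, and the step of an at least 14-fold lower number from compound 1 to compound 2 (1.15 log units; beyond the scatter) shows the opposite movement when the 2-(trifluoromethyl)phenyl was replaced by a halogen-bearing phenyl. The step that the two limits leave unreadable from compound 1 to compound 3 cannot be read, as both ends are limits.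

Compound 4 carries a phenyl bearing a single fluorine, closer in kind to the aryl of compound 2 than to that of compound 3. Because compound 2 gives 2830 nM, a large drop is expected for compound 4, an at least 6.6-fold lower number from compound 3 to compound 4 (0.82 log units; beyond the scatter). A value that again sits at the edge of what this assay reports cannot be excluded. Compound 4 is accordingly estimated at 6000 nM, with a range from 1500 nM to 40000 nM.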

Compound 4, half-maximal inhibitory concentration: 10200 nM
Beside the measured number, compound 4's estimate is 1.7-fold (0.23 log units) below it; the measured number falls inside the stated range.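

The 3-fluorophenyl group shows that an aryl on this aromatic nitrogen can bring the number in this assay away from the limit without the 4-bromo-2-fluorophenyl group of compound 2, as seen in an at least 3.9-fold lower number from compound 3 to compound 4 (0.59 log units; beyond the scatter) and in an at least 3.9-fold lower number from compound 1 to compound 4 (0.59 log units; beyond the scatter). Among the four compounds, the two aryls carrying trifluoromethoxy or trifluoromethyl sit at the limit, while the two carrying only ring halogens give numbers, and no compound shown goes against this. The halogen-bearing aryls are still not interchangeable, since the change shows a 3.6-fold higher number from compound 2 to compound 4 (0.56 log units; beyond the scatter), which gives the position a graded response rather than a simple split between a number and the limit.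

The step between the two compounds at the limit cannot be read, and neither compound has a number of its own: the limit of > 40000 nM in this assay, at which 2 of the 4 values shown sit. What the compers shown leave open is whether the bromine or the fluorine of compound 2 accounts for its lower number, and how an unsubstituted phenyl, or a phenyl carrying an amine or a carboxylic acid, would behave at this nitrogen.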